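This account rests on a few compounds, and the source may have more. Where it says the series, first, only, none or still open, it means among the compounds named here.

Compound 1 `Cc1cc(=O)oc2cc(OCc3cn(-c4cccc(F)c4)nn3)ccc12`: in an ADME assay on Huh-7 cells (Homo sapiens) for cytotoxicity, read by MTT assay, with a stated time of 72 h (a higher number here means that more compound is tolerated, a lower number that less compound is tolerated), compound 1 gives only a limit, > 100 ug/mL.
Compound 2 `Cc1cc(F)ccc1-n1cc(COc2ccc3c(C)cc(=O)oc3c2)nn1`: in this assay compound 2 gives only a limit, > 100 ug/mL.

Compound 2 thus stands at the limit, where both measured values sit (the limit of > 100 ug/mL in this assay, at which 2 of the 2 values shown sit), and the step that the two limits leave unreadable from compound 1 to compound 2 cannot be read. Compound 3 `Cc1ccc(-n2cc(COc3ccc4c(C)cc(=O)oc4c3)nn2)c(Cl)c1` differs from compound 2 by 2-chloro-4-methylphenyl in place of 4-fluoro-2-methylphenyl on an aromatic nitrogen. Going by the values given here, no measured step bears on this change, so no shift beyond the scatter is expected, and compound 3 is expected to sit again at or near the limit. For compound 3 the estimate in this assay is 150 ug/mL, within 70 ug/mL to 300 ug/mL. The expected step is a step that the limit leaves unreadable from compound 2 to compound 3.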

Compound 3, half-maximal cytotoxic concentration: > 100 ug/mL
Compound 3 ended at the assay's limit (the forecaster's own chance of this, stated with the estimate: 85%); the middle value is on the limit's open side.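

No step can be read among compound 1, compound 2 and compound 3 in this assay, since each gives only a limit: the limit of > 100 ug/mL in this assay, at which 3 of the 3 values shown sit.

The compounds shown leave open how much of each is actually tolerated, and whether changing the group on the aromatic nitrogen alters it.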